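Methoxy in place of ethyl in a series without numbers

A few compounds are considered here, and "the series" means these few. Any claim that something is new, unique, unknown or untested is made for them only; others in the source may bear on it.

Of the compounds shown here, three have been tested in an assay on HCC1954 cells for inhibition of phosphatidylinositol 4,5-bisphosphate 3-kinase catalytic subunit beta isoform (Homo sapiens) (a higher number here means that more compound is needed for the effect, a lower number that less compound is needed), and none of them gave a number. Compound 1 `Cc1nn2c(O)cc(C3CCOCC3)nc2c1Cc1cccc(C(F)(F)F)c1C` reached only the limit of > 31600 nM in this assay. Compound 2 `Cc1c(Cc2cnn3c(O)cc(-c4ccncc4)nc23)cccc1C(F)(F)F` likewise stopped at the limit of > 31600 nM. Compound 3 `CCc1nn2c(O)cc(-c3ccncc3)nc2c1Cc1cccc(Cl)c1Cl` also sits at a limit, > 31600 nM, so its standing among the values shown is the same as that of the other two: the limit of > 31600 nM in this assay, at which 3 of the 3 values shown sit. Going by the values given here, no pair of measured compounds differs in a single place, so the series offers no measured step to lean on.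

Compound 4 `COc1nn2c(O)cc(-c3ccncc3)nc2c1Cc1cccc(Cl)c1Cl` differs from compound 3 by one change: methoxy in place of ethyl on an aromatic carbon. With every measured compound at the limit, the size of the step from compound 3 to compound 4 cannot be read from the data; what can be said is that nothing in the three measured values points to a move away from the limit. The estimated step that the limit leaves unreadable from compound 3 to compound 4 is therefore expected to be none beyond the scatter. Compound 4 is expected to give 40000 nM in this assay, with a range from 8000 nM to 200000 nM, most likely again reported only as a limit.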

Compound 4, half-maximal effective concentration: > 31600 nM
Compound 4: only a limit was reported; the forecaster's own chance of this, stated with the estimate: 80%; the middle value lies beyond the limit too.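

Compound 3 and compound 4 both ended at a limit in this assay, so no step can be read for methoxy in place of ethyl on an aromatic carbon. The compounds shown leave open which change to the shared core, if any, would give a number rather than a limit, since all of them share one reading: the limit of > 31600 nM in this assay, at which 4 of the 4 values shown sit.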